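The compounds below may be only part of what the source reports. "The series", "measured", "known", "first", "only" and "open" are said of these compounds alone.

Of the compounds shown here, three that share one core have been measured in a functional assay on SGC-7901 cells (Homo sapiens) for antiproliferative activity, read by MTT assay, with a stated time of 24 h; a lower number here means a stronger inhibitor, a higher number a weaker inhibitor. Compound 1 `Cc1cccc(-n2cc(-c3ccc(NS(=O)(=O)c4c[nH]c(=O)[nH]c4=O)cc3)nn2)c1` gives 17500 nM in this assay. Compound 2 `O=c1[nH]cc(S(=O)(=O)Nc2ccc(-c3cn(-c4ccccc4F)nn3)cc2)c(=O)[nH]1` gives 7270 nM in this assay. Compound 3 `O=c1[nH]cc(S(=O)(=O)Nc2ccc(-c3cn(-c4ccc(F)cc4)nn3)cc2)c(=O)[nH]1` gives no number in this assay but only a limit, > 20000 nM. That value stands at the limit of > 20000 nM in this assay, at which 1 of the 3 values shown sits, so compound 3 is placed only by a range, above the other two. The three steps among them are a 2.4-fold lower number from compound 1 to compound 2 (0.38 log units; beyond the scatter), an at least 1.1-fold higher number from compound 1 to compound 3 (0.05 log units; that floor lies within the scatter) and an at least 2.7-fold higher number from compound 2 to compound 3 (0.43 log units; beyond the scatter).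

Compound 4 `O=c1[nH]cc(S(=O)(=O)Nc2ccc(-c3cn(-c4cccc(Cl)c4)nn3)cc2)c(=O)[nH]1` differs from compound 3 in one place: 3-chlorophenyl in place of 4-fluorophenyl on an aromatic nitrogen. Among the measured compounds shown here, two measured steps bear on it, since both end at the 4-fluorophenyl compound. The step of an at least 1.1-fold higher number from compound 1 to compound 3 (0.05 log units; that floor lies within the scatter) starts from a 3-methylphenyl compound and has a floor within the scatter, while an at least 2.7-fold higher number from compound 2 to compound 3 (0.43 log units; beyond the scatter) lies beyond it. Compound 4 carries a 3-chlorophenyl group, and compound 1 a 3-methylphenyl group, so compound 4 is expected to sit near compound 1, which means a change of about an at least 1.1-fold lower number from compound 3 to compound 4 (0.04 log units; that floor lies within the scatter) from the limit, though a second limit would not be surprising. In this assay compound 4 is estimated at 18000 nM, between 6000 nM and 45000 nM.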

Compound 4, half-maximal inhibitory concentration: 2460 nM
For compound 4 the middle estimate is 7.3-fold (0.86 log units) above the measured one, outside the stated range (below it).
By their numbers in this assay, from the lowest: compound 4; then compound 2; then compound 1. At a limit, above all of these: compound 3.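

Before compound 4, no aryl group on the aromatic nitrogen had gone below the 2-fluorophenyl compound in this assay, and the 3-chlorophenyl group now does, with a 3.0-fold lower number from compound 2 to compound 4 (0.47 log units; beyond the scatter) and a 7.1-fold lower number from compound 1 to compound 4 (0.85 log units; beyond the scatter), the second being a swap of chloro for methyl on an aromatic carbon, so the identity of the group on the phenyl ring matters here, and compound 4 is the strongest of the four. The change from 4-fluorophenyl to 3-chlorophenyl gives an at least 8.1-fold lower number from compound 3 to compound 4 (0.91 log units; beyond the scatter), which shows that this place on the aromatic nitrogen separates compounds well beyond the scatter. Compound 3 itself is held only by a limit, so the size of that step is a floor and not a measured gap: the limit of > 20000 nM in this assay, at which 1 of the 4 values shown sits.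

The compounds shown leave open whether the gain belongs to the chloro group itself or would also appear with a bromo, a methoxy or an amine in its place on the phenyl ring. They also leave open what lies behind the step, since no measured property of these groups is given.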